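The compounds below may be only part of what the source reports. "The series", "measured", "known", "first", "only" and "open" are said of these compounds alone.

Measured compounds:
Compound 1 `C[C@H]1[C@H](NCc2cccs2)C[C@H]2C[C@@H]1C2(C)C`: 25000 nM
Compound 2 `C[C@H]1[C@H](NCc2ccoc2)C[C@H]2C[C@@H]1C2(C)C`: a limit of > 100000 nM
Compound 3 `CCOc1ccsc1CN[C@@H]1C[C@H]2C[C@@H]([C@H]1C)C2(C)C`: 50000 nM

In an ADME assay on MDCK cells (Canis lupus familiaris) for cytotoxicity, read by microscopy, with a stated time of 48 h (a lower number here means that less compound is tolerated, a higher number that more compound is tolerated), compound 1 gives 25000 nM, the lowest of the two numbers shown. Its nearest neighbour is compound 3, at 50000 nM, and the step of a 2.0-fold higher number from compound 1 to compound 3 (0.30 log units; within the scatter) stays within the scatter. Compound 2 reports only a limit in this assay, > 100000 nM, so the step of an at least 4.0-fold higher number from compound 1 to compound 2 (0.60 log units; beyond the scatter) is known only as a lower bound; this rests on (the limit of > 100000 nM in this assay, at which 1 of the 3 values shown sits).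

Compound 4 `C[C@H]1[C@H](NCc2cc(C3CCCCC3)cs2)C[C@H]2C[C@@H]1C2(C)C` differs from compound 1 by a single change, (cyclohexyl in place of hydrogen on an aromatic carbon). The step that bears most directly on it is a 2.0-fold higher number from compound 1 to compound 3 (0.30 log units; within the scatter), which stays within the scatter. On that basis no shift beyond the scatter is expected in this assay, and the step from compound 1 to compound 4 is estimated as a 1.3-fold lower number from compound 1 to compound 4 (0.10 log units; within the scatter). Compound 4 is therefore expected to give about 20000 nM, within a range from 6000 nM to 60000 nM.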

Compound 4, minimum cytotoxic concentration: 780 nM
For compound 4 the middle estimate is 26-fold (1.41 log units) above the measured one; measured number outside the range, below it.
By their numbers in this assay, from the lowest: compound 4; then compounds 1 and 3 (each within the scatter of the next). At a limit, above all of these: compound 2.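

In this assay, cyclohexyl in place of hydrogen gives a 32-fold lower number from compound 1 to compound 4 (1.51 log units; beyond the scatter), showing that a substituent on this aromatic carbon, two ring bonds from the ring sulfur, can shift the number far beyond the scatter. Ethoxy in place of hydrogen on an aromatic carbon gave a 2.0-fold higher number from compound 1 to compound 3 (0.30 log units; within the scatter), so substitution on this ring does not bring a large step in every case, although those two changes differ in both the group and its place. Nothing shown here accounts for the size of the cyclohexyl step.

As far as these compounds go, whether a methyl, a phenyl or a piperidine on the same aromatic carbon would give a step of similar size remains open. So does whether cyclohexyl would have a similar effect on the furan-3-yl ring of compound 2.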